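Notes on compound 4: formyl in place of methoxy

The source may report more compounds than this note shows. Statements on the series, on what has been measured and on what is new or still open speak of the compounds shown alone.

Measured in a functional assay on SK-N-MC cells (Homo sapiens) for cytotoxicity, read by MTT assay, with a stated time of 72 h; on this read-out higher numbers stand for weaker inhibition and lower numbers for stronger inhibition:
- compound 1 `O=c1[nH]c(/C=C/c2ccccc2)nc2ccccc12`: 1390 nM
- compound 2 `COc1ccccc1/C=C/c1nc2ccccc2c(=O)[nH]1`: 2880 nM
- compound 3 `COc1ccc(/C=C/c2nc3ccccc3c(=O)[nH]2)cc1`: > 6250 nM

Compound 3 stands at the limit of > 6250 nM in this assay, at which 1 of the 3 values shown sits, which is a limit and not a number. Compound 4 `O=Cc1ccc(/C=C/c2nc3ccccc3c(=O)[nH]2)cc1` has formyl in place of methoxy on an aromatic carbon, para to a large group: formyl in place of methoxy on an aromatic carbon.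

For the measured compounds named here, no measured compound carries formyl, so the evidence is indirect. Going by the values given here, two measured steps bear on the change, both methoxy in place of hydrogen on an aromatic carbon. The more direct one is an at least 4.4-fold higher number from compound 1 to compound 3 (0.65 log units; beyond the scatter), since it involves the same carbon that changes in compound 4. The other is a 2.1-fold higher number from compound 1 to compound 2 (0.32 log units; beyond the scatter). Both steps run towards higher numbers, so a compound without methoxy may sit lower than compound 3, and compound 1 at 1390 nM marks where the hydrogen version lies. Going by these compounds, whether formyl behaves like hydrogen is untested, and a result reported only as a limit remains possible.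

A modest move towards lower numbers is therefore expected in this assay, estimated as an at least 2.5-fold lower number from compound 3 to compound 4 (0.39 log units; beyond the scatter). For compound 4 the estimated value is 2500 nM, with an expected range from 700 nM to 6250 nM.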

Compound 4, half-maximal inhibitory concentration: > 6250 nM
Compound 4: a limit, no number; the forecaster's own chance of this, stated with the estimate: 25%; middle value at least 2.5-fold (0.39 log units) from the limit.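

In this assay compound 4 gives > 6250 nM, which is a limit and not a number. Formyl in place of hydrogen on this aromatic carbon gives an at least 4.4-fold higher number from compound 1 to compound 4 (0.65 log units; beyond the scatter), so methoxy is no longer the only group at this carbon that goes with a higher number than hydrogen. The step between compound 3 and compound 4 cannot be read, because both compounds sit at the same limit: the limit of > 6250 nM in this assay, at which 2 of the 4 values shown sit.

Going by these compounds, the actual values of compound 3 and compound 4 remain unknown, so formyl and methoxy cannot be placed in any order at this carbon. Also open, on these data alone, is whether an amine or a carboxylic acid on this carbon would give a number rather than a limit in this assay, and whether formyl on the aromatic carbon that carries methoxy in compound 2 would give a readable value.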